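Side-chain swap to a carboxy in an acylglycine series

A few compounds are considered here, and "the series" means these few. Any claim that something is new, unique, unknown or untested is made for them only; others in the source may bear on it.

Compound 1 `N=C(N)NCCC[C@H](NC(=O)CN(c1nc(Cl)nc2[nH]cnc12)C1CC1)C(=O)O` in a functional assay on the whole organism (Tail, strain ICR) with Mus musculus as the target, in the tail flick test, with a stated time of 150 min, at a dose of 25 umol/kg by the oral route (on this read-out lower numbers stand for a weaker effect and higher numbers for a stronger effect at the one dose given), gives 7.19%, the second highest of three numbers. Compound 3 `N=C(N)NCCC[C@H](NC(=O)CN(c1nc(Cl)nc2[nH]cnc12)C1CC1)C(=O)OCc1ccccc1` gives 6.12%, and compound 2 `C[C@@H](O)[C@H](NC(=O)CN(c1nc(Cl)nc2[nH]cnc12)C1CC1)C(=O)OCc1ccccc1` gives 12.8%; both lie within the scatter of compound 1. Compound 4 `O=C(O)C[C@H](NC(=O)CN(c1nc(Cl)nc2[nH]cnc12)C1CC1)C(=O)O` differs from compound 1 by a group of 3 heavy atoms (1 carbon, 2 oxygen; no ring) in place of a group of 6 heavy atoms (3 carbon, 3 nitrogen; no ring), on a saturated chain carbon, two bonds along the chain from an amide-type nitrogen and a carbonyl carbon. The step nearest in kind is the side-chain exchange a number 6.7 percentage points lower from compound 2 to compound 3 (within the scatter); the ester step a number 1.1 percentage points lower from compound 1 to compound 3 (within the scatter) also changed nothing beyond the scatter. On this basis no shift beyond the scatter is expected for compound 4 in this assay, the expected step being a number 0.2 percentage points lower from compound 1 to compound 4 (within the scatter). Compound 4 is estimated at 7%, within 1% to 16%.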

Compound 4, a percentage reported as activity, at one dose (the size of the read-out at that dose, not a potency): 11.6%
For compound 4 the middle estimate is 4.6 percentage points below the measured one, and the stated range covers the measured number.
By their numbers in this assay, from the lowest: compounds 3, 1, 4 and 2 (each within the scatter of the next).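

On the saturated chain carbon, two bonds along the chain from an amide-type nitrogen and a carbonyl carbon, carboxy in place of the group of 6 heavy atoms gives a number 4.4 percentage points higher from compound 1 to compound 4 (within the scatter) in this assay. The earlier side chains held no carboxy, so this position now tolerates one with no shift beyond the scatter, with the free acid of compound 1 kept. Nothing available bears on the reason for this result.

Open, as far as these compounds go, is whether an amine or a longer chain ending in a carboxylic acid at this position would move the read-out beyond the scatter. Also open, from the compounds shown here alone, is how a benzyl ester of compound 4 would read.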